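Removing a Methyl Group from a Fluoropyrimidine Antiproliferative

The source may report more compounds than this note shows. Statements on the series, on what has been measured and on what is new or still open speak of the compounds shown alone.

Of the compounds shown here, two of a shared core have been tested so far in a functional assay on PC-3 cells (Homo sapiens) for antiproliferative activity, read by MTT assay, with a stated time of 48 h; a higher number here means a weaker inhibitor, a lower number a stronger inhibitor. Compound 1 `CS(=O)(=O)c1ccc(Nc2ncc(F)c(Nc3nc4ccccc4s3)n2)cc1` gives 2830 nM in this assay. Compound 2 `Cc1ccc2nc(Nc3nc(Nc4ccc(S(N)(=O)=O)cc4)ncc3F)sc2c1` gives 4960 nM in this assay, the higher of the two numbers; its nearest neighbour is compound 1, and the gap between them lies within the usual scatter of repeated measurements, so the two cannot be told apart on these numbers. Compound 1 and compound 2 differ in more than one place, so no single change can be read out of them.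

Compound 3 `NS(=O)(=O)c1ccc(Nc2ncc(F)c(Nc3nc4ccccc4s3)n2)cc1` has not yet been measured. It differs from compound 2 in one place: hydrogen in place of methyl on an aromatic carbon, on an aromatic carbon of a six-membered aromatic ring of carbon only, part of a fused system of two rings. Among the measured compounds shown here, no measured pair shows what removing a methyl group does here, so the step is uncertain; a small change, perhaps toward a lower number, or none beyond the scatter seems most likely. For compound 3 the expected value in this assay is 3500 nM, with a range from 1500 nM to 9000 nM. This amounts to an expected step of a 1.4-fold lower number from compound 2 to compound 3 (0.15 log units; within the scatter).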

Compound 3, half-maximal inhibitory concentration: > 50000 nM
Compound 3 ended at the assay's limit; the forecaster's own chance of this, stated with the estimate: 3%; middle value at least 14-fold (1.15 log units) from the limit.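

The value for compound 3 is a limit of the assay and not a number, so the steps to it give only a minimum size: the limit of > 50000 nM in this assay, at which 1 of the 3 values shown sits.

In this assay, among the compounds shown here, removing one methyl group from the aromatic carbon of the six-membered ring gives an at least 10-fold higher number from compound 2 to compound 3 (1.00 log units; beyond the scatter), which shows that this single carbon matters far more here than the earlier compounds could reveal, since compound 1 and compound 2 differ in more than one place. Putting amino in place of methyl on the sulfonyl sulfur, the only other difference in this set, gives an at least 17-fold higher number from compound 1 to compound 3 (1.24 log units; beyond the scatter), so among these three compounds a methyl group in either place goes with a measurable value, while compound 3, which has neither, sits at the limit.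

Going by these compounds, the true size of both steps stays unknown, and so does the value of a compound carrying methyl in both places. On these data alone, it is also open whether an ethyl or methoxy group on that aromatic carbon, or a dimethylamino group on the sulfonyl sulfur, would behave as methyl does.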